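Para-chloro for para-trifluoromethyl in a urea series

This account rests on a few compounds, and the source may have more. Where it says the series, first, only, none or still open, it means among the compounds named here.

Measured so far:
Compound 1: `O=C(Nc1cccc(C(F)(F)F)c1)N[C@H]1CC[C@H](Oc2cccc(C(F)(F)F)c2)CC1` — 1300 nM
Compound 2: `O=C(Nc1cccc(C(F)(F)F)c1)N[C@H]1CC[C@H](Oc2ccc(C(F)(F)F)cc2)CC1` — 460 nM

For the measured compounds named here, compound 2 carries the lower of the two numbers in a functional assay on CRL2813 cells (Homo sapiens) for cytotoxicity, read by sulforhodamine B assay, with a stated time of 5 days; on this read-out higher numbers stand for weaker inhibition and lower numbers for stronger inhibition; it is separated from compound 1 by a 2.8-fold lower number from compound 1 to compound 2 (0.45 log units; beyond the scatter), the only step recorded. Compound 3, `O=C(Nc1cccc(C(F)(F)F)c1)N[C@H]1CC[C@H](Oc2ccc(Cl)cc2)CC1`, is the next compound to be tested in this assay. It differs from compound 2 by chloro in place of trifluoromethyl on an aromatic carbon. Going by the values given here, no measured pair here exchanges one of these two groups for the other, so the recorded step from compound 1 to compound 2 does not speak to this change; it only shows that the group on the oxygen-linked ring can shift the number by a modest amount. Among the compounds with values here, with no direct precedent, the expected step is a 1.4-fold higher number from compound 2 to compound 3 (0.15 log units; within the scatter), small and possibly within the scatter. Compound 3 is therefore estimated at 650 nM, with a range from 250 nM to 1700 nM.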

Compound 3, half-maximal inhibitory concentration: 2000 nM
Compound 3: the middle estimate sits 3.1-fold (0.49 log units) below what was measured, outside the stated range (above it).
By their numbers in this assay, from the lowest: compound 2; then compounds 1 and 3 (each within the scatter of the next).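

In this assay this place on the oxygen-linked ring proves more sensitive than the earlier pair could show: chloro in place of trifluoromethyl gives a 4.3-fold higher number from compound 2 to compound 3 (0.64 log units; beyond the scatter). These two groups are therefore not interchangeable here, and the lowest number in the set stays with the 4-(trifluoromethyl)phenyl group of compound 2. The other comparison, a 1.5-fold higher number from compound 1 to compound 3 (0.19 log units; within the scatter), shows that 4-chlorophenyl and 3-(trifluoromethyl)phenyl cannot be told apart on this read-out. No measurement here explains the size of the step from trifluoromethyl to chloro.

Still open, going by these compounds, is whether a methoxy group or a nitrile at this place would give a number nearer that of compound 2 or that of compound 3. Also open, on these data alone, is whether the same exchange would have a similar effect with a different group on the other side of the urea.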